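The source may hold more compounds than are shown below. What is called first, only, known or untested is meant among the compounds shown, and "the series" means these compounds.

Among the compounds with values here, in a functional assay on PC-3 cells (Homo sapiens) for antiproliferative activity, with a stated time of 72 h (on this read-out higher numbers stand for weaker inhibition and lower numbers for stronger inhibition), compound 2 `CCN(C)Cc1c(OC)cc(OC)c(C(=O)/C=C/c2ccccc2Cl)c1O` gives 3 nM, the lowest of the numbers so far, while compound 1 `COc1cc(OC)c(C(=O)/C=C/c2ccccc2Cl)c(O)c1CN(C)CC(=O)O` gives 12500 nM. Compound 3 `CCN(CC)Cc1c(OC)cc(OC)c(C(=O)/C=C/c2ccccc2Cl)c1O` departs from compound 2 by a single change: methyl in place of hydrogen on a saturated chain carbon bound to an amine nitrogen. In words, this is methyl in place of hydrogen on a saturated chain carbon bound to an amine nitrogen, turning ethyl(methyl)amino into diethylamino. Within the data shown here, only one measured step bears on it, a 4200-fold lower number from compound 1 to compound 2 (3.62 log units; beyond the scatter), and that step is large. However, it exchanges carboxy for methyl, a different change from the one at hand, so its size cannot simply be carried over. Among the measured compounds shown here, no measured step isolates the added methyl, and only a small change in this assay is expected, with no clear direction beyond the scatter. The estimated step is a 1.7-fold higher number from compound 2 to compound 3 (0.22 log units; within the scatter). For compound 3, the expected value is 5 nM, within an estimated range of 1.5 nM to 25 nM.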

Compound 3, half-maximal inhibitory concentration: 4200 nM
For compound 3 the middle estimate is 840-fold (2.92 log units) below the measured one; measured number above the stated range.
By their numbers in this assay, from the lowest: compound 2; then compound 3; then compound 1.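

At this saturated chain carbon bound to an amine nitrogen, a single added methyl moves the read-out in this assay sharply, with a 1400-fold higher number from compound 2 to compound 3 (3.15 log units; beyond the scatter), so ethyl(methyl)amino and diethylamino are not interchangeable here. Compounds 1 and 2 alone left open whether losing the carboxy was enough for a low number, but diethylamino also carries no carboxy and gives only a modest step, with a 3.0-fold lower number from compound 1 to compound 3 (0.47 log units; beyond the scatter), so the outcome depends on the exact amine substituents. Nothing at hand accounts for the size of the step from compound 2 to compound 3.

The compounds shown leave open whether dimethylamino or a ring amine such as piperidine or morpholine would lie nearer compound 2 or compound 3. They also leave open how a longer chain, such as propyl on the amine nitrogen, would read.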